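The source may hold more compounds than are shown below. What is called first, only, known or untested is meant among the compounds shown, and "the series" means these compounds.

Measured so far:
- compound 1, `C#CCn1cc(C(=O)NC(CC(=O)Nc2ccccc2)c2ccccc2)c(=O)c2cc(F)c(Cl)nc21`: in a functional assay on A549 cells (Homo sapiens) for cytotoxicity, read by MTT assay, with a stated time of 72 h (a higher number here means a weaker inhibitor, a lower number a stronger inhibitor), compound 1 gives > 10000 nM, which is a limit of the assay and not a number.
- compound 2, `C#CCn1cc(C(=O)NC(CC(=O)Nc2ccccn2)c2ccccc2)c(=O)c2ccc(Cl)nc21`: in this assay compound 2 gives > 10000 nM, again a limit of the assay.

Among the measured compounds shown here, compound 1 therefore has no numeric place in this assay; it sits at the limit, and the only other value shown sits there too, as the limit of > 10000 nM in this assay, at which 2 of the 2 values shown sit, records. For the measured compounds named here, no step between two measured compounds exists in this set, so nothing about the effect of a single change has been measured.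

The compound to be measured next is compound 3, `C#CCn1cc(C(=O)NC(CC(=O)NC2CCCCC2)c2ccccc2)c(=O)c2cc(F)c(Cl)nc21`. Relative to compound 1 the change is cyclohexyl in place of phenyl on an amide-type nitrogen; the core and the rest of the chain are kept.

With compound 1 and compound 2 both at the limit, no direction for this change can be read from the data. The expectation for the step from compound 1 to compound 3 in this assay is a step that the limit leaves unreadable from compound 1 to compound 3, which is meant as no change beyond the scatter. Compound 3 is thus expected to give about 15000 nM in this assay, within a range of 4000 nM to 60000 nM, most likely reported again as a limit rather than a number.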

Compound 3, half-maximal inhibitory concentration: > 10000 nM
Compound 3 ended at the assay's limit; the forecaster's own chance of this, stated with the estimate: 70%; the middle value is on the limit's open side.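

In this assay compound 3 gives > 10000 nM, a limit of the assay and not a number. Compound 1 also stands at a limit, so the change from compound 1 to compound 3 cannot be read as a step. The compounds shown leave open which structures in this series, if any, would give a numeric value, as all of them sit at one mark: the limit of > 10000 nM in this assay, at which 3 of the 3 values shown sit.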